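A few compounds are considered here, and "the series" means these few. Any claim that something is new, unique, unknown or untested is made for them only; others in the source may bear on it.

Compound 3 `O=C(O)Cc1sc(C(c2ccc(F)cc2)c2ccc(F)cc2)nc1-c1ccncc1` gives the lowest number of the three measured compounds in an in vitro assay on HEK385-7 cells for displacement of a labelled ligand from prostaglandin D2 receptor 2 (Homo sapiens) (a higher number here means a weaker inhibitor, a lower number a stronger inhibitor), at 5.3 nM. Compound 2 `COc1cc(-c2nc(C(c3ccc(F)cc3)c3ccc(F)cc3)sc2CC(=O)O)ccn1` gives 29 nM in this assay, and compound 1 `O=C(O)Cc1sc(C(c2ccc(F)cc2)c2ccc(F)cc2)nc1-c1ccnc(N2CCC2)c1` gives 660 nM. The steps of a 5.5-fold lower number from compound 2 to compound 3 (0.74 log units; beyond the scatter) and a 120-fold lower number from compound 1 to compound 3 (2.10 log units; beyond the scatter) show hydrogen on the pyridin-4-yl ring outperforming methoxy and azetidin-1-yl there, while the two substituted rings are set apart by a 23-fold lower number from compound 1 to compound 2 (1.36 log units; beyond the scatter). Compound 4 `O=C(O)Cc1sc(C(c2ccc(F)cc2)c2ccc(F)cc2)nc1-c1cc(F)nc(F)c1` carries 2,6-difluoropyridin-4-yl in place of pyridin-4-yl on an aromatic carbon. All measured steps concern substituents on that same ring and every replacement of hydrogen there raised the number, so a step toward a higher number is expected for compound 4, though smaller in size than a 5.5-fold lower number from compound 2 to compound 3 (0.74 log units; beyond the scatter). Compound 4 is therefore expected to give 15 nM in this assay, between 4 nM and 60 nM, an estimated step of a 2.8-fold higher number from compound 3 to compound 4 (0.45 log units; beyond the scatter).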

Compound 4, half-maximal inhibitory concentration: 5.4 nM
Beside the measured number, compound 4's estimate is 2.8-fold (0.44 log units) above it, within the range that was stated.
By their numbers in this assay, from the lowest: compounds 3 and 4 (each within the scatter of the next); then compound 2; then compound 1.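

With a 1.0-fold higher number from compound 3 to compound 4 (0.01 log units; within the scatter), 2,6-difluoropyridin-4-yl is the only replacement for pyridin-4-yl shown that leaves the number in this assay within the scatter, so substitution on this ring does not always raise it. This ring also keeps the distance from the other substituted rings, with a 5.4-fold lower number from compound 2 to compound 4 (0.73 log units; beyond the scatter) and a 120-fold lower number from compound 1 to compound 4 (2.09 log units; beyond the scatter) in the same direction. Nothing measured here explains these differences among the groups. From the compounds shown here alone, whether one fluorine alone would suffice remains open, as does the outcome with chlorine or methyl in place of both fluorines.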